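The source may report more compounds than this note shows. Statements on the series, on what has been measured and on what is new or still open speak of the compounds shown alone.

In a functional assay on HepG2 cells (Homo sapiens), read by MTT assay, with a stated time of 48 h (on this read-out higher numbers stand for weaker inhibition and lower numbers for stronger inhibition), compound 3 (`CCn1c(C(=O)NCCN)ccc1C(CC)(CC)c1ccc(OCC(O)C(C)(C)C)c(C)c1`) gives 176 nM. Compound 1 (`CCn1c(C(=O)NCCN)ccc1C(CC)(CC)c1ccc(OCC(=O)C(C)(C)C)c(C)c1`) gives 180 nM, within the scatter of compound 3, and these two share the low end of the three numbers. Compound 2 (`CCn1c(C(=O)NCCN(C)C)ccc1C(CC)(CC)c1ccc(OCC(O)C(C)(C)C)c(C)c1`) gives 870 nM.

Compound 4 (`CC[C@@H](C)[C@H](NC(=O)c1ccc(C(CC)(CC)c2ccc(OCC(O)C(C)(C)C)c(C)c2)n1CC)C(=O)O`) keeps the rest of compound 3 and changes the amide side chain: 1-carboxy-2-methylbutyl in place of 2-aminoethyl on an amide-type nitrogen. In words, 1-carboxy-2-methylbutyl stands in place of 2-aminoethyl on an amide-type nitrogen.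

Two measured steps can be weighed. The first, a 1.0-fold lower number from compound 1 to compound 3 (0.01 log units; within the scatter), lies on a saturated chain carbon bound to an oxygen on an aromatic ring, a place left unchanged in compound 4, so it offers little guidance. The second, a 4.9-fold lower number from compound 2 to compound 3 (0.69 log units; beyond the scatter), is the only one in the side chain that now changes, and it replaces only amino with dimethylamino. The change to compound 4 is much larger, since the terminal amine is lost altogether. Going by the values given here, no measured compound carries a carboxy group or lacks that amine, so the size of the step is an extrapolation and the range must stay wide.

A move to a higher number in this assay is expected, larger than the step from the dimethylamino side chain. The estimated step is an 11-fold higher number from compound 3 to compound 4 (1.06 log units; beyond the scatter). For compound 4 the expected value is 2000 nM, with an estimated range of 350 nM to 12000 nM.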

Compound 4, half-maximal inhibitory concentration: 127 nM
The estimate for compound 4 lay 16-fold (1.20 log units) above the measured number, outside the stated range (below it).
By their numbers in this assay, from the lowest: compounds 4, 3 and 1 (each within the scatter of the next); then compound 2.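

In this assay, going by these compounds alone, the side chain on the amide-type nitrogen proves far more permissive than the earlier compounds could show: with 1-carboxy-2-methylbutyl in place of 2-aminoethyl, the step is a 1.4-fold lower number from compound 3 to compound 4 (0.14 log units; within the scatter), so 2-aminoethyl is not needed for a number in this range. The same group also stands clear of 2-(dimethylamino)ethyl, with a step of a 6.9-fold lower number from compound 2 to compound 4 (0.84 log units; beyond the scatter), which leaves compound 2 as the only one of the three side chains with a separated number, while compound 3 and compound 4 share the low end despite very different chains. No measurement here bears on why these side chains give this order.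

From the compounds shown here alone, it remains open whether the carboxylic acid or the branched sec-butyl part of 1-carboxy-2-methylbutyl matters more, a question that a methyl ester, a primary carboxamide or a plain carboxymethyl chain on the same amide-type nitrogen would address. The compounds shown also leave open how the opposite configuration at the stereocentres of 1-carboxy-2-methylbutyl, or a longer chain between the amide-type nitrogen and the carboxylic acid, would read.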